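The source may report more compounds than this note shows. Statements on the series, on what has been measured and on what is new or still open speak of the compounds shown alone.

In a functional assay on Ehrlich cells (Mus musculus) for antiproliferative activity, read by trypan blue exclusion, with a stated time of 2 h, tested at 25 ug/mL (a lower number here means a weaker effect, a higher number a stronger effect of the compound at the concentration tested), compound 2 `COc1ccc(C2C(C#N)=C(N)N(c3ccc(S(N)(=O)=O)cc3)C3=C2C(=O)CCC3)cc1` gives 50%, the lower of the two numbers shown. Compound 1 `N#CC1=C(N)N(c2ccc(S(N)(=O)=O)cc2)C2=C(C(=O)CCC2)C1c1ccc(O)cc1` gives 95%, and the step of a number 45 percentage points lower from compound 1 to compound 2 (beyond the scatter) came with methyl in place of hydrogen on an oxygen on an aromatic ring. Compound 3 `COc1cc(CC2C(C#N)=C(N)N(c3ccc(S(N)(=O)=O)cc3)C3=C2C(=O)CCC3)ccc1O` differs from compound 2 by 4-hydroxy-3-methoxybenzyl in place of 4-methoxyphenyl on a saturated ring carbon. Within the data shown here, that single step is the only one bearing on this change, and the entering group again carries a hydroxyl, so compound 3 is expected to rise by a number 20 percentage points higher from compound 2 to compound 3 (beyond the scatter) in this assay, with wide uncertainty. Compound 3 is therefore estimated at 70%, between 40% and 95%.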

Compound 3, a percentage reported as activity, at one concentration (the size of the read-out at that concentration, not a potency): 50%
Compound 3: middle estimate off by 20 percentage points, on the high side; the measured number falls inside the stated range.
By their numbers in this assay, from the lowest: compounds 2 and 3 (each within the scatter of the next); then compound 1.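

In this assay, the entering 4-hydroxy-3-methoxybenzyl group carries a hydroxyl, yet the step gave no change at the digits printed from compound 2 to compound 3 (within the scatter). Set against 4-hydroxyphenyl on the same saturated ring carbon, it gave a number 45 percentage points lower from compound 1 to compound 3 (beyond the scatter), so among these compounds a hydroxyl on the aromatic ring does not by itself go with the high number. Nothing available explains this result. As far as these compounds go, the change brings in the added carbon and the methoxy together, so their separate contributions stay open. Also open, from the compounds shown here alone, is how an amine or a carboxylic acid on that aromatic ring would read here.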